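Moving the acid from a ring onto an open chain

The source may report more compounds than this note shows. Statements on the series, on what has been measured and on what is new or still open speak of the compounds shown alone.

Compound 1 `O=C(O)[C@@H]1CCCN1C(=O)/C=C/c1ccncc1-c1ccc2ccccc2c1`: "not determined" (no result reported) in an assay on a protein complex for inhibition of CDK8/Cyclin C (Homo sapiens), with a stated time of 1 h; on this read-out lower numbers stand for stronger inhibition and higher numbers for weaker inhibition
Compound 2 `CCOC(=O)/C=C/c1ccncc1-c1ccc2[nH]ccc2c1`: 107 nM
Compound 3 `Cn1ncc2cc(-c3cnccc3/C=C/C(=O)N3CCOCC3)ccc21`: 356 nM

Compound 1 stands with "not determined" (no result reported) in this assay, so nothing places it among the measured compounds. Compound 2 gives 107 nM and compound 3 gives 356 nM in this assay, the two numbers that frame the shared core. Compound 4 `O=C(O)CCNC(=O)/C=C/c1ccncc1-c1ccc2ccccc2c1` differs from compound 1 by (2-carboxyethyl)amino in place of 2-carboxypyrrolidin-1-yl on a carbonyl carbon. With no number for compound 1, no step in this assay can be sized or given a direction, and only the spread shown by compound 2 and compound 3 guides expectation. Compound 4 is therefore estimated at 300 nM, expected to fall between 60 nM and 1500 nM.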

Compound 4, half-maximal inhibitory concentration: 870 nM
Beside the measured number, compound 4's estimate is 2.9-fold (0.46 log units) below it, and the stated range covers the measured number.
By their numbers in this assay, from the lowest: compound 2; then compound 3; then compound 4.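

In this assay, within the data shown here, compound 1 stands at "not determined" (no result reported) and compound 4 at 870 nM, so no step between them can be read. On these data alone, what replacing 2-carboxypyrrolidin-1-yl with (2-carboxyethyl)amino does to inhibition stays open. Nothing shown offers an explanation for the value of compound 4.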